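This account rests on a few compounds, and the source may have more. Where it says the series, first, only, none or still open, it means among the compounds named here.

Working notes on the series, all in an assay for binding affinity to Alpha-1B adrenergic receptor (Homo sapiens); a higher number here means a weaker inhibitor, a lower number a stronger inhibitor. Compound 1 `COc1cccc(Cc2nn(C[C@H]3CCCN3C)c(=O)c3ccccc23)c1` gives only > 1990 nM in this assay, which is a limit and not a number. Compound 2 `CCCCCc1nn(C[C@H]2CCCN2C)c(=O)c2ccccc12` gives 1000 nM in this assay. Within the data shown here, compound 3 `CN1CCC[C@@H]1Cn1nc(Cc2ccc(O)cc2)c2ccccc2c1=O` gives 398 nM in this assay, the lowest of the two numbers so far; the nearest is compound 2, and the step of a 2.5-fold lower number from compound 2 to compound 3 (0.40 log units; beyond the scatter) lies beyond the scatter. The step of an at least 5.0-fold lower number from compound 1 to compound 3 (0.69 log units; beyond the scatter) runs the same way, while an at least 1.9-fold lower number from compound 1 to compound 2 (0.29 log units; that floor lies within the scatter) stays within the scatter.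

Compound 4 `COC(=O)c1ccc(Cc2nn(C[C@H]3CCCN3C)c(=O)c3ccccc23)cc1` is not yet measured. It differs from compound 3 by methoxycarbonyl in place of hydroxy on an aromatic carbon. Among the measured compounds shown here, the measured steps of a 2.5-fold lower number from compound 2 to compound 3 (0.40 log units; beyond the scatter) and an at least 5.0-fold lower number from compound 1 to compound 3 (0.69 log units; beyond the scatter) both single out the 4-hydroxyphenyl variant as the one with the lowest number, and compound 1, bearing 3-methoxyphenyl rather than 4-hydroxyphenyl, sits at the limit of > 1990 nM in this assay, at which 1 of the 3 values shown sits. Removing the hydroxy in favour of methoxycarbonyl is therefore expected to raise the number for compound 4 in this assay, by a modest step of a 3.3-fold higher number from compound 3 to compound 4 (0.51 log units; beyond the scatter). Compound 4 is estimated at 1300 nM, within 400 nM to 4000 nM.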

Compound 4, inhibition constant: > 1990 nM
Compound 4: no number, only a limit (the forecaster's own chance of this, stated with the estimate: 30%); middle value at least 1.5-fold (0.18 log units) away from the limit.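

Replacing hydroxy with methoxycarbonyl on this aromatic carbon, para to a large group, leaves the rest of compound 3 unchanged and gives an at least 5.0-fold higher number from compound 3 to compound 4 (0.69 log units; beyond the scatter). The earlier steps shown here exchanged the whole group on the saturated chain carbon, whereas this one shows that a change at this single ring position is enough to lose the lowest number. In this assay compound 4 gives > 1990 nM, which is a limit and not a number, and the same limit recurs in the series: the limit of > 1990 nM in this assay, at which 2 of the 4 values shown sit.

Going by these compounds, the true size of the step stays open, as it has only a floor. Also open, on these data alone, is whether the number of compound 3 is tied to hydroxy itself or would hold with an amine, a carboxylic acid or a methoxy group at this position.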